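Swapping the side chain on the amide-bearing carbon

The compounds below may be only part of what the source reports. "The series", "measured", "known", "first", "only" and "open" are said of these compounds alone.

Compound 2 `CC(C)[C@H](NC(=O)CN(c1nc(Cl)nc2[nH]cnc12)C1CC1)C(=O)OCc1ccccc1` stands highest of the three measured compounds in a functional assay on the whole organism (Tail, strain ICR) with Mus musculus as the target, in the tail flick test, with a stated time of 60 min, at a dose of 25 umol/kg by the oral route (on this read-out lower numbers stand for a weaker effect and higher numbers for a stronger effect at the one dose given), giving 55.5%. Its nearest neighbour is compound 1 `O=C(CN(c1nc(Cl)nc2[nH]cnc12)C1CC1)NCC(=O)OCc1ccccc1`, which gives 41.9%, and furthest away is compound 3 `O=C(CN(c1ncnc2c1ncn2C1CCCCO1)C1CC1)N[C@@H](CCC(=O)OCc1ccccc1)C(=O)OCc1ccccc1`, which gives 34.7%. Among the compounds with values here, the only measured step at the position now in question is the one a number 13.6 percentage points higher from compound 1 to compound 2 (beyond the scatter). Compound 4 `O=C(CN(c1nc(Cl)nc2[nH]cnc12)C1CC1)N[C@@H](CCC(=O)OCc1ccccc1)C(=O)OCc1ccccc1` differs from compound 2 as follows: 2-(benzyloxycarbonyl)ethyl in place of isopropyl on a saturated chain carbon bound to an amide-type nitrogen and a carbonyl carbon. Within the data shown here, no measured step shows what replacing isopropyl by 2-(benzyloxycarbonyl)ethyl does on this core. Compound 3 carries the same 2-(benzyloxycarbonyl)ethyl group but a different core, so its value only hints that this side chain can sit on a weaker compound. Weighing the gain seen in compound 1 to compound 2 against the lower standing of compound 3, the step from compound 2 to compound 4 in this assay is expected to be modestly downward, a number 10.5 percentage points lower from compound 2 to compound 4 (beyond the scatter). Compound 4 is therefore estimated at 45%, in a range from 28% to 62%.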

Compound 4, a percentage reported as activity, at one dose (the size of the read-out at that dose, not a potency): 53.7%
The estimate for compound 4 lay 8.7 percentage points below the measured number; the measured number falls inside the stated range.
By their numbers in this assay, from the lowest: compounds 3 and 1 (each within the scatter of the next); then compounds 4 and 2 (each within the scatter of the next).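

In this assay, placing 2-(benzyloxycarbonyl)ethyl instead of isopropyl on the saturated chain carbon gives a number 1.8 percentage points lower from compound 2 to compound 4 (within the scatter) and so leaves the read-out unchanged, even though the entering group brings a six-membered aromatic ring and two hydrogen-bond acceptors that isopropyl lacks. Set against hydrogen at the same place, the group gives a number 11.8 percentage points higher from compound 1 to compound 4 (beyond the scatter) and thus joins isopropyl, so the gain over hydrogen at this position now rests on two quite different side chains rather than one. Nothing available explains why these two side chains give numbers so alike.

Going by these compounds, it remains open whether a small group such as methyl on this carbon would already give the same gain over hydrogen. On these data alone, it is equally open whether a side chain ending in a free carboxylic acid or an amine would hold the effect at this level.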